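The compounds below may be only part of what the source reports. "The series", "measured", "known", "first", "only" and "open" are said of these compounds alone.

Measured in an ADME assay on HUVEC cells (Homo sapiens) for inhibition, read by CCK-8 assay, with a stated time of 24 h, in the presence of a further agent that is not named here; on this read-out lower numbers stand for stronger inhibition and higher numbers for weaker inhibition:
Compound 1 `Cc1cccc(-n2cc(-c3ccc(/C=C4\C(=O)Nc5ccccc54)cc3)nn2)c1`: 13700 nM
Compound 2 `Cc1cccc(-n2cc(-c3ccc(/C=C4\C(=O)Nc5ccc(F)cc54)cc3)nn2)c1`: 9880 nM
Compound 3 `O=C1Nc2ccc(F)cc2C1=Cc1ccc(-c2cn(-c3ccc(Cl)cc3)nn2)cc1`: 19600 nM

Compound 2 reads 9880 nM, and neither compound 1 nor compound 3 lies beyond the scatter from it. The series therefore shows no clear separation in this assay.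

The next compound, compound 4 `N#Cc1cccc(-n2cc(-c3ccc(/C=C4\C(=O)Nc5ccc(F)cc54)cc3)nn2)c1`, differs from compound 2 by one substitution, (cyano in place of methyl on an aromatic carbon). This puts cyano in place of methyl on an aromatic carbon, turning 3-methylphenyl into 3-cyanophenyl.

Among the measured compounds shown here, no measured step makes this exchange. For the measured compounds named here, the only measured step between compounds differing in one place is a 1.4-fold lower number from compound 1 to compound 2 (0.14 log units; within the scatter), and it is a different change, fluoro in place of hydrogen on an aromatic carbon. It bears only indirectly, as a sign that one small substitution has so far moved the number little. Going by the values given here, compound 3, at 19600 nM, also stays within the scatter of compound 2, though no single-place step links them.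

With so little evidence, no shift beyond the scatter is expected in this assay. The expected change is small, with an estimated 1.2-fold higher number from compound 2 to compound 4 (0.08 log units; within the scatter). For compound 4 the estimate is 12000 nM, with an expected range from 5000 nM to 28000 nM.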

Compound 4, half-maximal inhibitory concentration: > 20000 nM
Compound 4 was reported as a limit (the forecaster's own chance of this, stated with the estimate: 5%); middle value at least 1.6-fold (0.22 log units) from the limit.
By their numbers in this assay, from the lowest: compounds 2, 1 and 3 (each within the scatter of the next). At a limit, above all of these: compound 4.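

In this assay compound 4 gives a limit of the assay and not a number, the only such reading among the compounds shown: the limit of > 20000 nM in this assay, at which 1 of the 4 values shown sits. Among the compounds shown here, the exchange of methyl for cyano on this aromatic carbon is the only measured change at this place, and it reads as an at least 2.0-fold higher number from compound 2 to compound 4 (0.30 log units; that floor lies within the scatter), which gives a floor rather than a size, and that floor does not clear the scatter. The earlier step concerned fluoro at another place in the core, whereas this one touches the 3-methylphenyl group itself and shows that turning it into 3-cyanophenyl brings no lower number, while a true shift beyond the scatter stays possible but unproven.

Going by these compounds, how far the true value of compound 4 lies past its limit remains open, so the size of this exchange cannot be stated. Also open, on these data alone, is whether a different group on this carbon, such as an amine, a carboxylic acid or a methoxy group, would give a measurable number, and whether it would differ from compound 2 by more than the scatter.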